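A few compounds are considered here, and "the series" means these few. Any claim that something is new, unique, unknown or untested is made for them only; others in the source may bear on it.

Of the compounds shown here, two sharing one core have been measured in an assay on isolated protein (Oryctolagus cuniculus) for binding affinity to Adrenergic receptor alpha-1 (Homo sapiens); a lower number here means a stronger inhibitor, a higher number a weaker inhibitor. Compound 1 `NCC1CCc2c1ccc(O)c2O` carries an amino group on a saturated chain carbon bound to a saturated ring carbon, and in this assay compound 1 gives 2250 nM. Compound 2 `CN(C)CC1CCc2c1ccc(O)c2O` carries a dimethylamino group in that place; in this assay compound 2 gives 6900 nM, the higher of the two numbers, and the step of a 3.1-fold higher number from compound 1 to compound 2 (0.49 log units; beyond the scatter) lies beyond the scatter. Compound 3 `CNCC1CCc2c1ccc(O)c2O` has not yet been measured. It differs from compound 2 by hydrogen in place of methyl on an amine nitrogen, so it stands partway back toward compound 1, with one methyl on the nitrogen instead of two or none. For the measured compounds named here, the only measured step that bears on this is a 3.1-fold higher number from compound 1 to compound 2 (0.49 log units; beyond the scatter), which added two methyls and raised the number modestly. Removing one of them is expected to lower the number by a smaller amount, and the expected step from compound 2 is a 1.8-fold lower number from compound 2 to compound 3 (0.25 log units; within the scatter). The estimate for compound 3 in this assay is 3900 nM, with a range from 1800 nM to 8500 nM.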

Compound 3, inhibition constant: 2000 nM
Compound 3: the middle estimate sits 2.0-fold (0.29 log units) above what was measured; the measured number falls inside the stated range.
By their numbers in this assay, from the lowest: compounds 3 and 1 (each within the scatter of the next); then compound 2.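

In this assay, taking one methyl off the nitrogen of compound 2 gives a 3.5-fold lower number from compound 2 to compound 3 (0.54 log units; beyond the scatter) and so undoes a change beyond the scatter. Going the other way along the series, a 1.1-fold lower number from compound 1 to compound 3 (0.05 log units; within the scatter) lies within the scatter, so the amino group of compound 1 and the methylamino group of compound 3 cannot be told apart in this assay. The earlier step, a 3.1-fold higher number from compound 1 to compound 2 (0.49 log units; beyond the scatter), showed only the effect of the two methyls together, whereas these steps place the whole readable change at the move from methylamino to dimethylamino, so a methyl in place of hydrogen on this nitrogen does not have one fixed effect.

The data shown offer no explanation for this difference between the two methyls. As far as these compounds go, it also remains open whether a larger group on this nitrogen, such as an ethyl or a benzyl, would behave like the methylamino group of compound 3 or the dimethylamino group of compound 2, and whether a longer chain between the ring carbon and the amine would keep the same pattern.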